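The source may report more compounds than this note shows. Statements on the series, on what has been measured and on what is new or still open speak of the compounds shown alone.

Measured compounds in an ADME assay on HEK293 cells (Homo sapiens) for cytotoxicity, with a stated time of 72 h; a lower number here means that less compound is needed, a higher number that more compound is needed for the effect:

Compound 1 `COc1ccc(NC(=O)Nc2cc(C)nc3ccccc23)cc1` — a limit of the assay, > 25000 nM.
Compound 2 `COc1ccc(NC(=O)Nc2cc(C)nc3ccccc23)cc1F` — a limit of the assay, > 25000 nM.
Compound 3 `Cc1cc(NC(=O)Nc2ncccc2C)c2ccccc2n1` — a limit of the assay, > 25000 nM.

Compound 2 stands at the limit of this assay, and no number is known for it. The same holds across the set: the limit of > 25000 nM in this assay, at which 3 of the 3 values shown sit. The step that leads from compound 1 to compound 2, fluoro in place of hydrogen on an aromatic carbon, is a step that the two limits leave unreadable from compound 1 to compound 2, so its size is not known. Compound 4 `Cc1cc(NC(=O)Nc2ccc(F)c(F)c2)c2ccccc2n1` has not been measured in this assay. It differs from compound 2 as follows: fluoro in place of methoxy on an aromatic carbon. For the measured compounds named here, the only measured step in this assay touches the same ring, and it is unreadable, so no size can be carried over to the step from compound 2 to compound 4. With every value known sitting at the limit, compound 4 is expected to sit there as well, with a step that the limit leaves unreadable from compound 2 to compound 4 that is expected to be no more than scatter. The estimate for compound 4 in this assay is therefore 30000 nM, within a range from 15000 nM to 100000 nM.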

Compound 4, half-maximal effective concentration: > 25000 nM
Compound 4 gave a limit, no number; the forecaster's own chance of this, stated with the estimate: 85%; the middle value is on the limit's open side.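

Compound 2 and compound 4 both give only a limit in this assay, not a number, so no step can be read between them: the limit of > 25000 nM in this assay, at which 4 of the 4 values shown sit. The compounds shown leave open at what concentration any of them reaches the half-maximal effect, and therefore how large any step in this assay is.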